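The source may report more compounds than this note shows. Statements on the series, on what has been measured and on what is new or still open speak of the compounds shown alone.

Of the compounds shown here, three have been tested in a functional assay on cardiac atrium for agonist activity at histamine H2 receptor (Cavia porcellus); on this read-out lower numbers stand for smaller maximal responses and higher numbers for larger maximal responses. Compound 1 `C[C@H](CC(=O)NC(=N)NCCCc1c[nH]cn1)c1ccccc1` gives 93%, and its stereoisomer compound 3 `C[C@@H](CC(=O)NC(=N)NCCCc1c[nH]cn1)c1ccccc1` gives 102%; the only difference between the two is a stereocentre at a saturated chain carbon, and the step of a number 9 percentage points higher from compound 1 to compound 3 (within the scatter) stays within the scatter, the change being (the fact that one of compounds 1 and 3 is drawn with a defined configuration and the other without, at the place where they differ). Compound 2 `Cc1nc(N)sc1CCCNC(=N)NC(=O)CC(C)c1ccccc1`, in which the shared core carries the aminothiazole side, gives 89% in this assay; this is the lowest of the three numbers, lying within the scatter of compound 1 and beyond the scatter of compound 3.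

The next compound, compound 4 `Cc1nc(N)sc1CCCNC(=N)NC(=O)CC(C)C1CCCCC1`, differs from compound 2 in one place: cyclohexyl in place of phenyl on a saturated chain carbon bound to two saturated chain carbons. Among the measured compounds shown here, no measured step concerns this change. For the measured compounds named here, the only step on record, from compound 1 to compound 3, concerns a stereocentre and not the phenyl, and it was within the scatter, so it offers no guide to the direction or size of the present change. On the numbers shown, all three compounds reach a high response in this assay, and the change is therefore expected to yield a step of a number 1 percentage points lower from compound 2 to compound 4 (within the scatter), no larger than the scatter. For compound 4 the expected value in this assay is 88%, with a range from 72% to 102%.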

Compound 4, largest response reached (Emax), in percent of the reference or control that the assay uses: 74%
Estimate against measurement, compound 4: 14 percentage points above; low and high end bracket the measured number.
By their numbers in this assay, from the lowest: compound 4; then compounds 2, 1 and 3 (each within the scatter of the next, the first and the last beyond it).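

Cyclohexyl in place of phenyl on a saturated chain carbon bound to two saturated chain carbons gives, in this assay, a number 15 percentage points lower from compound 2 to compound 4 (beyond the scatter), so this position is the first place in the series where a single change moves the maximal response beyond the scatter, whereas a number 9 percentage points higher from compound 1 to compound 3 (within the scatter) did not. The response at this position is therefore sensitive to the ring it carries, even though phenyl and cyclohexyl match in heavy atoms, carry no hydrogen-bond donors or acceptors and have no net charge; what separates them in the computed comparison is that one ring is aromatic and the other is not. Among the compounds shown here, the only evidence at hand concerns how a stereocentre is drawn in another pair of compounds, so it does not bear on this change and offers no explanation for the step.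

The compounds shown leave open whether a cyclopentyl or a thienyl group at this position would keep the response of the phenyl compound or lose it as cyclohexyl does. They also leave open whether the same exchange would give a step of similar size on the imidazole-bearing side of the series, and whether the configuration at the chain carbon matters once cyclohexyl is in place.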